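Capping a hydroxy group in the cytotoxicity series

A few compounds are considered here, and "the series" means these few. Any claim that something is new, unique, unknown or untested is made for them only; others in the source may bear on it.

Values in a functional assay on SH-SY5Y cells (Homo sapiens) for cytotoxicity, read by MTT assay, with stated times of 24 h and 4 h (on this read-out lower numbers stand for an effect already at smaller amounts and higher numbers for an effect only at larger amounts of compound), for the measured compounds:
compound 1 `COc1cc(CNC(=O)/C=C/c2ccccc2O)ccc1O` gives 9760 nM
compound 2 `COc1cc(CNC(=O)/C=C/c2ccccc2O)ccc1OCc1nc(C)c(C)nc1C` gives 5300 nM
compound 3 `COc1cc(/C=C/C(=O)NCc2ccc(OCc3nc(C)c(C)nc3C)c(OC)c2)ccc1OCc1nc(C)c(C)nc1C` gives 11100 nM

The three numbers lie close together. Compound 1 sits in the middle of them, and its gaps to compound 2 and compound 3 are both within the scatter. Compound 4 `COc1cc(CNC(=O)/C=C/c2ccccc2OC)ccc1O` is the next to be read against compound 1. The change is methyl in place of hydrogen on an oxygen on an aromatic ring, which is hydroxy to methoxy.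

Going by the values given here, only one measured step bears on this change. It is a 1.8-fold lower number from compound 1 to compound 2 (0.27 log units; within the scatter), with (3,5,6-trimethylpyrazin-2-yl)methyl in place of hydrogen on an oxygen on an aromatic ring. That step concerns a different oxygen and a much larger group than compound 4 carries, so it is only a loose guide. Among the compounds with values here, compound 3 differs from compound 1 in more than one place and gives no clean step. Within the data shown here, no measured pair covers methyl on this oxygen.

With so little to go on, no shift beyond the scatter is expected in this assay, and no direction can be argued with confidence. The expected step is a 1.1-fold lower number from compound 1 to compound 4 (0.06 log units; within the scatter) and would stay small. For compound 4 the estimated value is 8500 nM, with an expected range from 4200 nM to 18000 nM.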

Compound 4, half-maximal effective concentration: 5980 nM
Compound 4: middle estimate off by 1.4-fold (0.15 log units), on the high side; the measured number falls inside the stated range.
By their numbers in this assay, from the lowest: compounds 2, 4, 1 and 3 (each within the scatter of the next, the first and the last beyond it).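

In this assay, going by these compounds alone, the first measured change at this oxygen gives a 1.6-fold lower number from compound 1 to compound 4 (0.21 log units; within the scatter), so replacing hydroxy with methoxy here does not move the number beyond the scatter, and the hydrogen on this oxygen is not needed for a read-out in this range. The other oxygen gave a similar result with a much larger group, a 1.8-fold lower number from compound 1 to compound 2 (0.27 log units; within the scatter), so in the two single-place steps available, neither capping group produces a shift beyond the scatter, and neither step goes against this. No measurement on hand explains the size of either step.

Still open, on these data alone, is whether a larger group on this oxygen, such as an ethyl, a longer chain, or a chain ending in an amine or a carboxylic acid, would shift the number beyond the scatter in this assay. Also open, as far as these compounds go, is whether methyl on the oxygen that carries the (3,5,6-trimethylpyrazin-2-yl)methyl group in compound 2 would read like that group, and whether (3,5,6-trimethylpyrazin-2-yl)methyl on the oxygen methylated in compound 4 would read like methyl.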